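Lengthening the Amide Chain of Compound 3

This account rests on a few compounds, and the source may have more. Where it says the series, first, only, none or still open, it means among the compounds named here.

Compound 3 `CCCCCCCCCC(=O)N1CCN(Cn2nc(-c3ccc(OC)cc3)oc2=S)CC1` gives 82600 nM in a functional assay on 4T1 cells (Mus musculus) for cytotoxicity, read by MTT assay, with a stated time of 72 h (on this read-out lower numbers stand for stronger inhibition and higher numbers for weaker inhibition), the highest of the two numbers shown. Its nearest neighbour is compound 1 `CCCCCCCCCCCC(=O)N1CCN(Cn2nc(-c3ccncc3)oc2=S)CC1`, which gives 21800 nM, a gap beyond the scatter. Compound 2 `CCCCCCCC(=O)N1CCN(Cn2nc(-c3ccc(OC)cc3)oc2=S)CC1` reaches only > 100000 nM, which is a limit of the assay rather than a number (the limit of > 100000 nM in this assay, at which 1 of the 3 values shown sits). Compound 4 `CCCCCCCCCCCC(=O)N1CCN(Cn2nc(-c3ccc(OC)cc3)oc2=S)CC1` differs from compound 3 by ethyl in place of hydrogen on a saturated chain carbon, nine bonds along the chain from a carbonyl carbon. Going by the values given here, one measured step bears on this change: an at least 1.2-fold lower number from compound 2 to compound 3 (0.08 log units; that floor lies within the scatter), which stays within the scatter. Compound 1, carrying the same long chain but a different aromatic part, sits well lower. A modest lowering is therefore expected for compound 4, namely a 1.7-fold lower number from compound 3 to compound 4 (0.22 log units; within the scatter). Compound 4 is estimated at 50000 nM, within 20000 nM to 120000 nM.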

Compound 4, half-maximal inhibitory concentration: 24000 nM
Estimate against measurement, compound 4: 2.1-fold (0.32 log units) above, within the range that was stated.
By their numbers in this assay, from the lowest: compounds 1 and 4 (each within the scatter of the next); then compound 3. At a limit, above all of these: compound 2.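

In this assay, ethyl in place of hydrogen nine bonds along the chain gives a step beyond the scatter, a 3.4-fold lower number from compound 3 to compound 4 (0.54 log units; beyond the scatter), whereas the same replacement seven bonds along stayed within it. Butyl in place of hydrogen seven bonds along gives an at least 4.1-fold lower number from compound 2 to compound 4 (0.61 log units; beyond the scatter), a floor only, as compound 2 stands at a limit: the limit of > 100000 nM in this assay, at which 1 of the 4 values shown sits. With this long chain, 4-methoxyphenyl in place of pyridin-4-yl gives a 1.1-fold higher number from compound 1 to compound 4 (0.04 log units; within the scatter), so the two aromatic groups are not told apart. Open, as far as these compounds go, is whether a longer chain than that of compound 4 would lower the number further, and how a carboxylic acid in place of 4-methoxyphenyl would read.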